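The source may report more compounds than this note shows. Statements on the series, on what has been measured and on what is new or still open speak of the compounds shown alone.

Values in an in vitro ADME assay on microsomes from liver (Homo sapiens) for metabolic stability (on this read-out higher numbers stand for fast clearance and lower numbers for slow clearance), each one a limit of the assay:

- compound 1 `Cc1cnc(NC(=O)c2cc(Oc3cnc(C(=O)N(C)C)cn3)c3cn(C)nc3c2)cn1`: < 8.5 mL/min/kg
- compound 2 `Cc1cnc(NC(=O)c2cc(Oc3ccc(S(C)(=O)=O)cc3)c3cn(C)nc3c2)cn1`: < 8 mL/min/kg
- compound 3 `Cc1cnc(NC(=O)c2cc(Oc3ccc(S(=O)(=O)C4CC4)cc3)c3cn(C)nc3c2)cn1`: < 8 mL/min/kg

None of the three compounds has a readable number, so no order can be drawn among them. Compound 3 is known only by its limit of < 8 mL/min/kg in this assay.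

Compound 4 `CNS(=O)(=O)c1ccc(Oc2cc(C(=O)Nc3cnc(C)cn3)cc3nn(C)cc23)cc1` has methylamino in place of cyclopropyl on a sulfonyl sulfur. The same difference, cut one bond further out, reads cyclopropylsulfonyl to methylsulfamoyl.

Going by the values given here, only one measured step touches this sulfonyl sulfur: a step that the two limits leave unreadable from compound 2 to compound 3. Among the compounds with values here, it offers no size to carry over, and no measured compound yet has methylamino there. The expectation therefore rests on compound 3, with its limit of < 8 mL/min/kg, and no change in either direction beyond the usual scatter is foreseen. The expected step is a number no lower from compound 3 to compound 4 (the limit leaves the size open). For compound 4 the estimated clearance is 8 mL/min/kg, within an expected range of 5 mL/min/kg to 14 mL/min/kg.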

Compound 4, clearance: < 8.6 mL/min/kg
Compound 4 gave a limit, no number; the forecaster's own chance of this, stated with the estimate: 70%; the middle value does not contradict the limit.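

Going by these compounds alone, compound 2, compound 3 and compound 4 are known only by limits in this assay, and no step among them can be read. The compounds shown leave open whether methyl, cyclopropyl or methylamino on the sulfonyl sulfur makes any difference to clearance.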